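Trifluoromethoxy for methoxy at the solubility limit

A few compounds are considered here, and "the series" means these few. Any claim that something is new, unique, unknown or untested is made for them only; others in the source may bear on it.

Both values come from a physicochemical assay for solubility, using the shake flask method, in simulated intestinal fluid, measured as kinetic solubility, with a stated time of 2 h, at 25 degrees C, at pH 6.5 (on this read-out higher numbers stand for higher solubility and lower numbers for lower solubility), and both are limits:
- Compound 1 `Cc1noc(-c2nc(C)c3c(c2N)C(=O)N(Cc2ccc(-c4ccncc4)cc2)C3=O)n1` gives < 5000 nM (a limit)
- Compound 2 `COc1ccc(CN2C(=O)c3c(C)nc(-c4nc(C)no4)c(N)c3C2=O)cc1` gives < 5000 nM (a limit)

Compound 2 stands only at its limit of < 5000 nM and has no number of its own. Compound 3 `Cc1noc(-c2nc(C)c3c(c2N)C(=O)N(Cc2ccc(OC(F)(F)F)cc2)C3=O)n1` differs from compound 2 in one place: trifluoromethyl in place of methyl on an oxygen on an aromatic ring. Among the measured compounds shown here, the one measured step that the two limits leave unreadable from compound 1 to compound 2 offers no size to carry over, and the limit of < 5000 nM in this assay, at which 2 of the 2 values shown sit, applies to both compounds. No step beyond the scatter is therefore expected in this assay in either direction. For compound 3 the estimate is 2500 nM (expected range 800 nM to 5000 nM), and the assay will probably report only a limit again. The expected change is a step that the limit leaves unreadable from compound 2 to compound 3 and no more.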

Compound 3, solubility: < 5000 nM
Compound 3: a limit, no number; the forecaster's own chance of this, stated with the estimate: 85%; the middle value does not contradict the limit.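

No size can be read for any step among compound 1, compound 2 and compound 3 in this assay, since all three stop at one shared limit: the limit of < 5000 nM in this assay, at which 3 of the 3 values shown sit.

Going by these compounds, how far each compound's true solubility lies from that limit, and whether methoxy and trifluoromethoxy differ at all, stays open.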